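Replacing the benzyl arm of compound 1 with a trifluoromethylphenyl group

This account rests on a few compounds, and the source may have more. Where it says the series, first, only, none or still open, it means among the compounds named here.

compound 1 `COc1ccc(F)cc1CNCCCNc1ccnc2cc(Cc3ccc(F)cc3Cl)ccc12` gives 9.47 in a physicochemical assay for acid dissociation
compound 2 `Fc1ccc(Oc2ccc3c(NCCCNCc4ccco4)ccnc3c2)cc1` gives 9.28 in this assay
compound 3 `Fc1ccc(Cc2ccc3c(NCCCNCc4ccco4)ccnc3c2)c(Cl)c1` gives 9.47 in this assay

Compound 1 stands level with compound 3, the two together at the top of three numbers, and compound 2 sits only a number 0.19 log units higher from compound 2 to compound 3 (within the scatter), a gap within the scatter. The new compound 4 `COc1ccc(F)cc1CNCCCNc1ccnc2cc(-c3ccc(C(F)(F)F)cc3)ccc12` differs from compound 1 in one place: 4-(trifluoromethyl)phenyl in place of 2-chloro-4-fluorobenzyl on an aromatic carbon. For the measured compounds named here, one measured step bears on this kind of change at an aromatic carbon of the shared core, namely a number 0.19 log units higher from compound 2 to compound 3 (within the scatter), and the step of no change at the digits printed from compound 1 to compound 3 (within the scatter) shows that swapping an aryl group elsewhere also left the number essentially untouched. The reading for compound 4 in this assay is therefore expected to show a number 0.07 log units lower from compound 1 to compound 4 (within the scatter), nothing beyond the scatter. The estimate for compound 4 is 9.4, with a range from 9.1 to 9.7.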

Compound 4, acid dissociation constant: 9.47
The estimate for compound 4 lay 0.07 log units below the measured number; measured number inside the range.
By their numbers in this assay, from the lowest: compounds 2, 1, 3 and 4 (each within the scatter of the next).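

In this assay, putting 4-(trifluoromethyl)phenyl in place of 2-chloro-4-fluorobenzyl on this aromatic carbon gives no change at the digits printed from compound 1 to compound 4 (within the scatter). The earlier step at this carbon came from compounds carrying the furan-2-yl arm, so a step within the scatter is now also seen with the 5-fluoro-2-methoxyphenyl arm and with a different incoming group. Nothing available explains why this reading holds.

Still open, going by these compounds, is whether a group carrying an amine or a carboxylic acid on this carbon would also leave the number within the scatter.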